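Swapping an Ortho Substituent: Trifluoromethoxy to Nitro

A few compounds are considered here, and "the series" means these few. Any claim that something is new, unique, unknown or untested is made for them only; others in the source may bear on it.

Compound 1 `Cc1cc(NC(=O)Nc2cccc(C(N)=O)c2)c2ccccc2n1`: 2 10^-6 cm/s
Compound 2 `CSc1ccccc1NC(=O)Nc1cc(C)nc2ccccc12`: 1260 10^-6 cm/s
Compound 3 `Cc1cc(NC(=O)Nc2ccccc2OC(F)(F)F)c2ccccc2n1`: 1110 10^-6 cm/s

In an ADME assay for permeability, using PAMPA, at pH 7.4 (a lower number here means that the compound crosses the layer more slowly, a higher number that the compound crosses the layer faster), compound 3 stands second highest of the three. Its nearest neighbour is compound 2, and the step of a 1.1-fold lower number from compound 2 to compound 3 (0.06 log units; within the scatter) lies within the scatter, so the two cannot be ordered. Compound 1 sits far lower, and its value differs from that of compound 3 by a gap well beyond the scatter.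

Compound 4 `Cc1cc(NC(=O)Nc2ccccc2[N+](=O)[O-])c2ccccc2n1` is not yet measured. It differs from compound 3 in one place: nitro in place of trifluoromethoxy on an aromatic carbon The change sits on an aromatic carbon of a six-membered aromatic ring of carbon only, ortho to a large group.

Going by the values given here, only one measured step touches that position, the exchange a 1.1-fold lower number from compound 2 to compound 3 (0.06 log units; within the scatter), and it was within the scatter. Among the compounds with values here, no step involving a nitro group has been measured, so nothing here tells how much, or in which direction, this particular swap moves the read-out. Compound 1 shows that a very different substituent on this ring can drop the number far, but its change is not the one made here.

For compound 4 the step of a 2.5-fold lower number from compound 3 to compound 4 (0.39 log units; beyond the scatter) is therefore expected to be modest, with a wide range, and the value is estimated at 450 10^-6 cm/s, between 100 10^-6 cm/s and 1200 10^-6 cm/s.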

Compound 4, apparent permeability: 204 10^-6 cm/s
Compound 4: the middle estimate sits 2.2-fold (0.34 log units) above what was measured, within the range that was stated.
By their numbers in this assay, from the lowest: compound 1; then compound 4; then compounds 3 and 2 (each within the scatter of the next).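

In this assay, going by these compounds alone, the one exchange known at this position gave a 1.1-fold lower number from compound 2 to compound 3 (0.06 log units; within the scatter) and so left methylsulfanyl and trifluoromethoxy unseparated. Nitro does stand apart from both groups: the swap from trifluoromethoxy gives a 5.4-fold lower number from compound 3 to compound 4 (0.74 log units; beyond the scatter) and the swap from methylsulfanyl gives a 6.2-fold lower number from compound 2 to compound 4 (0.79 log units; beyond the scatter) and so this place on the ring clearly responds to the choice of substituent, even though the first exchange there hinted at no such thing. No measurement here accounts for the difference, so the drop stands as a plain observation.

As far as these compounds go, with only methylsulfanyl, trifluoromethoxy and nitro compared at this place, it stays open whether the lower number is peculiar to nitro or would also come with other groups, such as an amine, a carboxylic acid or a nitrile. From the compounds shown here alone, it is equally open whether nitro would lower the number by a similar amount on another core, or when attached at a different carbon of the same ring.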